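Amide in place of ether on the saturated ring carbon

This account rests on a few compounds, and the source may have more. Where it says the series, first, only, none or still open, it means among the compounds named here.

Three compounds of the shared core have numbers in a functional assay on HEK293 cells for agonist activity at G-protein coupled receptor 39 (Homo sapiens), read by scintillation proximity assay and inositol phosphate accumulation, with a stated time of 75 min, in the presence of a further agent that is not named here; a lower number here means that less compound is needed, a higher number that more compound is needed for the effect. Compound 1 `Cc1nn(-c2ncnc3nc[nH]c23)c2c1C(C(=O)NCc1ccc(F)cc1)CC(=O)N2` gives 4 nM, compound 2 `CCCCCCCCOC1CC(=O)Nc2c1c(C)nn2-c1ncnc2nc[nH]c12` gives 8 nM, and compound 3 `Cc1nn(-c2ncnc3nc[nH]c23)c2c1C(OCCn1nccc1C)CC(=O)N2` gives 10 nM. Compound 3 carries the highest of the three numbers; its gap to compound 2 lies within the scatter, its gap to compound 1 lies beyond it. Among the measured compounds shown here, the one measured step, a 1.3-fold higher number from compound 2 to compound 3 (0.10 log units; within the scatter), exchanges one end of the ether side chain for another and leaves the number within the scatter.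

Compound 4 `Cc1nn(-c2ncnc3nc[nH]c23)c2c1C(C(=O)N(C)c1nccs1)CC(=O)N2` is not yet measured. Relative to compound 3 the change is a group of 9 heavy atoms (5 carbon, 2 nitrogen, 1 oxygen, 1 sulfur; one five-membered aromatic ring with 2 hetero atoms) in place of a group of 9 heavy atoms (6 carbon, 2 nitrogen, 1 oxygen; one five-membered aromatic ring with 2 hetero atoms), on a saturated ring carbon. For the measured compounds named here, no measured step covers this exchange of an ether for an amide, so the expectation rests on what two values show. Compound 1 carries a carbamoyl group on the same saturated ring carbon and gives 4 nM; set against compound 3 at 10 nM, the two values show that an amide at this position went with the lower number, although the amide substituents of compound 1 and compound 4 are not the same. A modest move towards the lower numbers is therefore expected, a 1.7-fold lower number from compound 3 to compound 4 (0.22 log units; within the scatter), close to the edge of the scatter. Compound 4 is estimated at 6 nM, with a range from 2 nM to 18 nM.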

Compound 4, half-maximal effective concentration: 18 nM
The estimate for compound 4 lay 3.0-fold (0.48 log units) below the measured number, within the range that was stated.
By their numbers in this assay, from the lowest: compounds 1, 2, 3 and 4 (each within the scatter of the next, the first and the last beyond it).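

In this assay, the step of a 1.8-fold higher number from compound 3 to compound 4 (0.26 log units; within the scatter) leaves the ether and the amide at this saturated ring carbon undistinguished, so a carbamoyl group at this place does not by itself go with a lower number. With the carbonyl kept, the step of a 4.5-fold higher number from compound 1 to compound 4 (0.65 log units; beyond the scatter) lies beyond the scatter, which shows that the number depends on the amine part of the amide, here methyl(1,3-thiazol-2-yl)amino in place of (4-fluorobenzyl)amino. Against the octyloxy ether, the step of a 2.3-fold higher number from compound 2 to compound 4 (0.35 log units; beyond the scatter) is also beyond the scatter, though modest, so the ring carbon tolerates both ethers and amides within a narrow span of numbers in these four compounds.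

No measurement at hand explains these differences.

The compounds shown leave open whether the gap between compound 1 and compound 4 follows the methyl on the amide nitrogen or the 1,3-thiazol-2-yl ring, which a secondary 1,3-thiazol-2-yl amide or an N-methyl-(4-fluorobenzyl) amide would separate, and how a carboxylic acid or a primary amine would read on the same ring carbon.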